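Diethylamino back on a longer chain: compound 3

The compounds below may be only part of what the source reports. "The series", "measured", "known", "first", "only" and "open" are said of these compounds alone.

Values in a functional assay on cells (Homo sapiens) for antiproliferative activity, read by MTT assay, with a stated time of 48 h (on this read-out higher numbers stand for weaker inhibition and lower numbers for stronger inhibition), for the measured compounds

- compound 1 `CCN(CC)CCn1c(N)c(-c2nc3ccccc3[nH]2)c2nc(C#N)c(C#N)nc21` gives 25400 nM
- compound 2 `N#Cc1nc2c(-c3nc4ccccc4[nH]3)c(N)n(CCCO)c2nc1C#N` gives > 50000 nM (a limit of the assay)

Compound 2 stands at a limit and not at a number, with the limit of > 50000 nM in this assay, at which 1 of the 2 values shown sits, as its only mark.

Compound 3 `CCN(CC)CCCCn1c(N)c(-c2nc3ccccc3[nH]2)c2nc(C#N)c(C#N)nc21` differs from compound 2 in its chain ((diethylamino)methyl in place of hydroxy on a saturated chain carbon, three bonds along the chain from an aromatic nitrogen) so that (diethylamino)methyl takes the place of hydroxy, which turns 3-hydroxypropyl into 4-(diethylamino)butyl.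

Among the compounds with values here, the one measured step that bears on this is an at least 1.9-fold higher number from compound 1 to compound 2 (0.29 log units; that floor lies within the scatter) where hydroxymethyl replaces diethylamino two bonds along the chain from an aromatic nitrogen. Its size is only a floor. Within the data shown here, the change to compound 3 runs the opposite way on a longer chain, and no measured pair tests chain length. The nearest anchor is compound 1 at 25400 nM with its 2-(diethylamino)ethyl chain.

A lower number is therefore expected in this assay with an at least 2.2-fold lower number from compound 2 to compound 3 (0.35 log units; beyond the scatter) as the estimated step. A second limit remains possible. Compound 3 is expected between 8000 nM and 50000 nM (estimated middle 22000 nM).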

Compound 3, half-maximal inhibitory concentration: 640 nM
Compound 3: the middle estimate sits 34-fold (1.54 log units) above what was measured, and the stated range ends above it.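

In this assay, within the data shown here, this is the first result in which chain length can be read with the diethylamino end group kept: a 40-fold lower number from compound 1 to compound 3 (1.60 log units; beyond the scatter), where 2-(diethylamino)ethyl takes the place of diethylamino on a saturated chain carbon, two bonds along the chain from an aromatic nitrogen. The diethylamino group on the shorter chain therefore gave no sign of what the 4-(diethylamino)butyl chain shows, and the change from 3-hydroxypropyl to that chain gives an at least 78-fold lower number from compound 2 to compound 3 (1.89 log units; beyond the scatter), a large step set against the earlier at least 1.9-fold higher number from compound 1 to compound 2 (0.29 log units; that floor lies within the scatter). Compound 2 stands at a limit and not at a number, and the step from it is only a floor: the limit of > 50000 nM in this assay, at which 1 of the 3 values shown sits.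

Still open, on these data alone, is whether the number falls steadily with chain length or reaches its lowest point at the butyl chain, which a 3-(diethylamino)propyl chain and a longer chain ending in diethylamino would test. Also open, as far as these compounds go, is how much depends on the amine itself: a 4-hydroxybutyl chain would separate the end group from chain length, and a pyrrolidine or morpholine on the butyl chain would test whether diethylamino can be replaced.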